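A few compounds are considered here, and "the series" means these few. Any claim that something is new, unique, unknown or untested is made for them only; others in the source may bear on it.

Measured compounds:
Compound 1 `Oc1cccc(-c2cc(-c3ccccc3C(F)(F)F)cc(-c3ccccc3O)n2)c1` gives 9010 nM in a functional assay on HCT-15 cells (Homo sapiens) for inhibition; on this read-out higher numbers stand for weaker inhibition and lower numbers for stronger inhibition.
Compound 2 `Oc1cccc(-c2cc(-c3cccc(C(F)(F)F)c3)cc(-c3ccccc3O)n2)c1` gives 6460 nM in this assay.
Compound 3 `Oc1ccc(-c2cc(-c3ccccc3C(F)(F)F)cc(-c3ccc(O)cc3)n2)cc1` gives > 50000 nM in this assay, which is a limit of the assay and not a number.

Compound 1 and compound 2 differ by one change, (3-(trifluoromethyl)phenyl in place of 2-(trifluoromethyl)phenyl on an aromatic carbon), and the step is a 1.4-fold lower number from compound 1 to compound 2 (0.14 log units; within the scatter). Compound 3 is at the limit of > 50000 nM in this assay, at which 1 of the 3 values shown sits. How the core of compound 3 differs from the core of compound 1 is not broken down here. Compound 4 `Oc1ccc(-c2cc(-c3cccc(C(F)(F)F)c3)cc(-c3ccc(O)cc3)n2)cc1` has not yet been measured; it differs from compound 3 by 3-(trifluoromethyl)phenyl in place of 2-(trifluoromethyl)phenyl on an aromatic carbon, the same kind of change as from compound 1 to compound 2, though here the place is meta to two 4-hydroxyphenyl groups rather than meta to a 2-hydroxyphenyl group and a 3-hydroxyphenyl group. Because the earlier step of a 1.4-fold lower number from compound 1 to compound 2 (0.14 log units; within the scatter) lay within the scatter, a step that the limit leaves unreadable from compound 3 to compound 4 is expected here, likely leaving compound 4 at the limit as well. Compound 4 is estimated at 60000 nM, between 25000 nM and 150000 nM.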

Compound 4, half-maximal inhibitory concentration: > 50000 nM
Compound 4 was reported as a limit (the forecaster's own chance of this, stated with the estimate: 70%); the middle value lies beyond the limit too.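

No step can be read from compound 3 to compound 4, as both values in this assay are limits and not numbers: the limit of > 50000 nM in this assay, at which 2 of the 4 values shown sit.

The compounds shown leave open whether 3-(trifluoromethyl)phenyl in place of 2-(trifluoromethyl)phenyl changes inhibition at all alongside two 4-hydroxyphenyl groups.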